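Adding bromo to compound 2: a small expected step

The source may report more compounds than this note shows. Statements on the series, on what has been measured and on what is new or still open speak of the compounds shown alone.

In a functional assay on MDA-MB-231 cells (Homo sapiens) for cytotoxicity, read by MTT assay, with a stated time of 48 h (on this read-out lower numbers stand for stronger inhibition and higher numbers for weaker inhibition), compound 1 (`COc1cc(-c2ocnc2-c2cc(Br)c(OC)c(OC)c2)ccc1SC`) gives 760 nM and compound 2 (`COc1cc(-c2ocnc2-c2cc(OC)c(OC)c(OC)c2)ccc1SC`) gives 850 nM as its value. The two stand level, and the step of a 1.1-fold higher number from compound 1 to compound 2 (0.05 log units; within the scatter) lies within the scatter. Compound 3 (`COc1cc(/C(=C\c2cccc(OC)c2SC)C(=O)O)cc(OC)c1OC`) gives > 20000 nM as its result, which is a limit of the assay and not a number. Within the data shown here, compound 2 therefore has only one numerical neighbour, and it is not separated from that neighbour.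

Compound 4 (`COc1cc(-c2ncoc2-c2cc(Br)c(SC)c(OC)c2)cc(OC)c1OC`) follows from compound 2 with bromo in place of hydrogen on an aromatic carbon, ortho to a methylsulfanyl group bromo in place of hydrogen on an aromatic carbon and meta to a methoxy group. Among the measured compounds shown here, one measured step bears on this change, and only indirectly. It exchanges bromo and methoxy at another place rather than adding bromo to a hydrogen-bearing carbon, yet the step of a 1.1-fold higher number from compound 1 to compound 2 (0.05 log units; within the scatter) shows that bromo was tolerated there without a change beyond the scatter. For the measured compounds named here, no measured compound carries bromo at the new place, so the expectation remains uncertain. The expected step of a 1.2-fold higher number from compound 2 to compound 4 (0.07 log units; within the scatter) stays within the scatter, though a larger move in either direction cannot be excluded. The estimated value for compound 4 is 1000 nM in this assay with an expected range from 250 nM to 5000 nM.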

Compound 4, half-maximal inhibitory concentration: 17900 nM
Estimate against measurement, compound 4: 18-fold (1.25 log units) below; measured number above the stated range.
By their numbers in this assay, from the lowest: compounds 1 and 2 (each within the scatter of the next); then compound 4. At a limit, above all of these: compound 3.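

Adding one bromo atom ortho to a methylsulfanyl group and meta to a methoxy group is not a neutral change in this assay: the result is a 21-fold higher number from compound 2 to compound 4 (1.32 log units; beyond the scatter). The earlier pair had shown bromo and methoxy standing level at another place on the molecule, and this result shows that such tolerance does not carry over to this hydrogen-bearing carbon, which was the one place where no measured compound had yet tested bromo. It also moves compound 4 out of the range of compound 1 and compound 2 and up towards the top of what this read-out reports as a number: the limit of > 20000 nM in this assay, at which 1 of the 4 values shown sits.

What the compounds shown leave open is whether the loss belongs to bromo itself or would follow any substituent at this carbon, for instance a fluorine atom, a hydroxyl, a methyl or an amine. With a single pair carrying the finding, they also cannot tell whether a smaller or a larger group here would give a step of another size.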